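Swapping the phenyl of compound 2 for pyridin-2-yl

A few compounds are considered here, and "the series" means these few. Any claim that something is new, unique, unknown or untested is made for them only; others in the source may bear on it.

Compound 1 `Oc1ccc(-c2cc(-c3ccc(Cl)cc3)nc(-c3ccsc3)c2)cc1` and compound 2 `Oc1ccc(-c2cc(-c3ccccc3)nc(-c3ccc(Cl)cc3)c2)cc1` share a core and differ only in one aromatic ring attached to it. In an assay on isolated protein for inhibition of DNA topoisomerase 1 (Homo sapiens), with a stated time of 30 min, tested at 100 uM (a higher number here means a stronger effect of the compound at the concentration tested, a lower number a weaker effect), compound 1 gives 47.7%, and compound 2 gives 68%. The difference, phenyl in place of thiophen-3-yl on an aromatic carbon, gave a number 20.3 percentage points higher from compound 1 to compound 2 (beyond the scatter). Among the compounds with values here, compound 2 therefore stands highest of the two numbers so far, with compound 1 the only neighbour.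

Compound 3 `Oc1ccc(-c2cc(-c3ccc(Cl)cc3)nc(-c3ccccn3)c2)cc1` is not yet measured. It differs from compound 2 by pyridin-2-yl in place of phenyl on an aromatic carbon.

Within the data shown here, only the one step from compound 1 to compound 2 bears on this change, and it shows that exchanging the aromatic ring at this place can shift the read-out modestly. Among the measured compounds shown here, no measured pair tells how a ring bearing a nitrogen behaves here. The step from compound 2 to compound 3 is therefore expected to be small, a number 10 percentage points lower from compound 2 to compound 3 (within the scatter), with some chance of a slight fall that stays near the scatter. Compound 3 is expected to give about 58%, within a range from 32% to 82%.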

Compound 3, a percentage reported as inhibition, at one concentration (the size of the read-out at that concentration, not a potency): 12.7%
Compound 3: the middle estimate sits 45.3 percentage points above what was measured; the measured number lies below the stated range.
By their numbers in this assay, from the lowest: compound 3; then compound 1; then compound 2.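

In this assay, this position proved far more sensitive than the earlier pair alone suggested: pyridin-2-yl in place of phenyl gave a number 55.3 percentage points lower from compound 2 to compound 3 (beyond the scatter), although both groups have the same count of heavy atoms and the entering ring differs by one ring nitrogen and one hydrogen-bond acceptor. Pyridin-2-yl also fell short of thiophen-3-yl, with a number 35 percentage points lower from compound 1 to compound 3 (beyond the scatter), so the three rings at this place rank phenyl, thiophen-3-yl, then pyridin-2-yl, with every step between them beyond the scatter. Nothing available accounts for the size of this fall.

As far as these compounds go, what pyridin-3-yl or pyridin-4-yl would give at this place remains open, and with it whether the fall follows the presence of a ring nitrogen as such or where that nitrogen sits in the ring. Also open, from the compounds shown here alone, are how a phenyl ring carrying an amine or a carboxylic acid would read here, and whether the three compounds would keep this order at other concentrations.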